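A Smaller Amine at the Chain End

The source may report more compounds than this note shows. Statements on the series, on what has been measured and on what is new or still open speak of the compounds shown alone.

Compound 1, `c1ccc(CNCCCCN(C[C@H]2Cc3ccccc3CN2)[C@H]2CCCc3cccnc32)cc1`, gives > 30000 nM in a functional assay on cells for agonist activity at C-X-C chemokine receptor type 4 (Homo sapiens), read by fluorescence and calcium flux, with a stated time of 90 s; a higher number here means that more compound is needed for the effect, a lower number that less compound is needed; this is a limit of the assay, not a number.
Compound 2, `c1ccc2c(c1)CN[C@@H](CN(CCCCNC1CCNCC1)[C@H]1CCCc3cccnc31)C2`, gives > 30000 nM in this assay, again only a limit.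
Compound 3, `CC1(C)CCC(NCCCCN(C[C@H]2Cc3ccccc3CN2)[C@H]2CCCc3cccnc32)CC1`, gives > 30000 nM in this assay, also a limit.

Compound 3 therefore sits at the limit of > 30000 nM in this assay, at which 3 of the 3 values shown sit, alongside the other two. The steps a step that the two limits leave unreadable from compound 1 to compound 2, a step that the two limits leave unreadable from compound 1 to compound 3 and a step that the two limits leave unreadable from compound 2 to compound 3 are all unreadable, so no change at the amine nitrogen has yet produced a measurable effect.

Compound 4, `CC(C)(N)CCCN(C[C@H]1Cc2ccccc2CN1)[C@H]1CCCc2cccnc21`, differs from compound 3 by a group of 4 heavy atoms (3 carbon, 1 nitrogen; no ring) in place of a group of 10 heavy atoms (9 carbon, 1 nitrogen; one six-membered non-aromatic ring of carbon only), on a saturated chain carbon, three bonds along the chain from an amine nitrogen. No measured step bears on this change, and nothing shown points to a gain. Compound 4 is therefore expected to remain near the limit, with an estimated step that the limit leaves unreadable from compound 3 to compound 4. The expected value of compound 4 is 40000 nM, within an estimated range from 8000 nM to 200000 nM.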

Compound 4, half-maximal effective concentration: > 30000 nM
Compound 4: a limit, no number (the forecaster's own chance of this, stated with the estimate: 75%); the middle value lies beyond the limit too.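

Compound 4 gives only a limit, as do compound 1, compound 2 and compound 3, so no new step among them can be read: the limit of > 30000 nM in this assay, at which 4 of the 4 values shown sit.

The compounds shown leave open which structural change, if any, would give a measurable value in this assay.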